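Chloro Added to the Aryl Ring of a Phenyl Enone Acid

This account rests on a few compounds, and the source may have more. Where it says the series, first, only, none or still open, it means among the compounds named here.

Measured compounds:
compound 1 `O=C(O)/C=C/C(=O)c1ccccc1`: 30600 nM
compound 2 `Cc1ccc(C)c(C(=O)/C=C/C(=O)O)c1`: 7860 nM
compound 3 `CCc1cc(CC)c(C(=O)/C=C/C(=O)O)c(CC)c1`: 6530 nM

Of the compounds shown here, three have been measured in a functional assay on HeLa cells (Homo sapiens) for inhibition, read by MTT assay, with a stated time of 72 h; on this read-out higher numbers stand for weaker inhibition and lower numbers for stronger inhibition. Compound 1 `O=C(O)/C=C/C(=O)c1ccccc1` gives the highest of the three numbers: compound 2 stands at a lower number that lies beyond the scatter, and compound 3 stands lower still, also beyond the scatter. For the measured compounds named here, no single-point step between two measured compounds is available, so the two alkylated compounds show only that substitution on the aryl ring of the shared core can move the number down.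

Compound 4 `O=C(O)/C=C/C(=O)c1ccc(Cl)cc1` has not yet been measured. It differs from compound 1 in one place: chloro in place of hydrogen on an aromatic carbon. On the evidence of compound 2 and compound 3, substitution on this ring has so far gone with lower numbers, and a step of that direction but smaller size is expected from compound 1 to compound 4, by a 2.0-fold lower number from compound 1 to compound 4 (0.31 log units; beyond the scatter), though a step within the scatter cannot be excluded. Compound 4 is therefore expected to give about 15000 nM in this assay, within a range from 5000 nM to 45000 nM.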

Compound 4, half-maximal inhibitory concentration: 25400 nM
The estimate for compound 4 lay 1.7-fold (0.23 log units) below the measured number; measured number inside the range.
By their numbers in this assay, from the lowest: compounds 3 and 2 (each within the scatter of the next); then compounds 4 and 1 (each within the scatter of the next).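

Chloro in place of hydrogen on an aromatic carbon, para to a group of 7 heavy atoms, gives a 1.2-fold lower number from compound 1 to compound 4 (0.08 log units; within the scatter) in this assay and so provides the first reading of a single group at a single place on this ring. Compound 2 and compound 3 each differ from compound 1 in more than one place, so they could not show this, and here one chloro at this position does not move the number beyond the scatter. Nothing measured here bears on why the step has this size.

On these data alone, it remains open whether an amine or a methoxy group in the same place would give a step beyond the scatter. Which of the methyl or ethyl groups of compound 2 and compound 3 go with their numbers also remains open.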